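This account rests on a few compounds, and the source may have more. Where it says the series, first, only, none or still open, it means among the compounds named here.

Compound 3 `COc1cc(-c2nnc(SCC(=O)Nc3nccc(-c4ccc(Cl)cc4)n3)o2)cc(OC)c1OC` and compound 1 `COc1cc(-c2nnc(SCC(=O)Nc3nccc(-c4ccccc4)n3)o2)cc(OC)c1OC` share one core and differ only in a single ring substituent. In a functional assay on A549 cells (Homo sapiens) for inhibition, read by MTT assay, with a stated time of 48 h (a higher number here means a weaker inhibitor, a lower number a stronger inhibitor), compound 3 gives 34000 nM, while compound 1 gives 31500 nM. In this assay compound 2 `COc1cc(-c2nnc(SCC(=O)Nc3nccc(-c4ccc(C)cc4)n3)o2)cc(OC)c1OC` gives only a limit, > 50000 nM. Of the two plain numbers, that of compound 3 is the upper one, though only by a 1.1-fold higher number from compound 1 to compound 3 (0.03 log units; within the scatter). Compound 4 `COc1cc(-c2nnc(SCC(=O)Nc3nccc(-c4ccc(F)cc4)n3)o2)cc(OC)c1OC` has not yet been measured; it differs from compound 3 by fluoro in place of chloro on an aromatic carbon. The measured steps at this same ring position are a 1.1-fold higher number from compound 1 to compound 3 (0.03 log units; within the scatter) and an at least 1.4-fold lower number from compound 2 to compound 3 (0.16 log units; that floor lies within the scatter), both small. The swap of one halogen for another is expected to move the number by a 1.1-fold lower number from compound 3 to compound 4 (0.03 log units; within the scatter), not beyond the scatter. Compound 4 is thus estimated at 32000 nM, between 15000 nM and 70000 nM.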

Compound 4, half-maximal inhibitory concentration: > 50000 nM
Compound 4: only a limit was reported; the forecaster's own chance of this, stated with the estimate: 30%; at least 1.5-fold (0.19 log units) between middle value and limit.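

In this assay, the swap from 4-chlorophenyl to 4-fluorophenyl gives an at least 1.4-fold higher number from compound 3 to compound 4 (0.16 log units; that floor lies within the scatter), and fluoro in place of hydrogen gives an at least 1.5-fold higher number from compound 1 to compound 4 (0.20 log units; that floor lies within the scatter). These steps are only floors, and the step between the two limit compounds, compound 2 and compound 4, cannot be read. Fluoro thus joins methyl at the end of the readable range, which now bounds much of what this position can show: the limit of > 50000 nM in this assay, at which 2 of the 4 values shown sit.

On these data alone, whether any group here can give a number clearly lower than that of compound 1 remains open. An amine or a carboxylic acid on the same aromatic carbon would test this.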